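A hydroxy group enters the side chain of compound 3

A few compounds are considered here, and "the series" means these few. Any claim that something is new, unique, unknown or untested is made for them only; others in the source may bear on it.

Compound 1 `C=CC[C@@H]1C[C@@H](c2ccc(Cl)c(Cl)c2)[C@H](NC(=O)c2cc(-c3c(Cl)cnn3C)c(Cl)o2)CN1` gives 990 nM
Compound 2 `Cn1ncc(Cl)c1-c1cc(C(=O)N[C@@H]2CN[C@H](CC(=O)NCC(O)CO)C[C@H]2c2ccc(Cl)c(Cl)c2)oc1Cl` gives 5900 nM
Compound 3 `CCC[C@@H]1C[C@@H](c2ccc(Cl)c(Cl)c2)[C@H](NC(=O)c2cc(-c3c(Cl)cnn3C)c(Cl)o2)CN1` gives 1620 nM

These numbers come from a functional assay on OVCAR-8 cells (Homo sapiens) for antiproliferative activity (a lower number here means a stronger inhibitor, a higher number a weaker inhibitor), and the three compounds share one core, differing only in a side chain. Compound 3 cannot be told apart from compound 1, with a 1.6-fold higher number from compound 1 to compound 3 (0.21 log units; within the scatter) as the whole gap. Compound 2 has the highest number of the three, and a 3.6-fold lower number from compound 2 to compound 3 (0.56 log units; beyond the scatter) shows how far compound 3 lies from it.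

Next comes compound 4 `Cn1ncc(Cl)c1-c1cc(C(=O)N[C@@H]2CN[C@H](CCO)C[C@H]2c2ccc(Cl)c(Cl)c2)oc1Cl` and its change is hydroxy in place of methyl on a saturated chain carbon, two bonds along the chain from a saturated ring carbon in that side chain: hydroxy in place of methyl on a saturated chain carbon, two bonds along the chain from a saturated ring carbon, so propyl becomes 2-hydroxyethyl.

Within the data shown here, two measured steps bear on this. The only side chain so far with hydroxy groups, (2,3-dihydroxypropyl)carbamoyl in place of vinyl, brought a 6.0-fold higher number from compound 1 to compound 2 (0.78 log units; beyond the scatter) and the present change is much smaller than that one. Ethyl in place of vinyl brought only a 1.6-fold higher number from compound 1 to compound 3 (0.21 log units; within the scatter) and shows that a small edit here can leave the number unmoved. A slightly higher number is therefore expected, probably not clearly beyond the scatter. The expected step is a 1.5-fold higher number from compound 3 to compound 4 (0.17 log units; within the scatter) and it remains an estimate. For compound 4 the estimated value is 2400 nM with 1100 nM to 5500 nM as the expected range.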

Compound 4, half-maximal inhibitory concentration: 610 nM
Estimate against measurement, compound 4: 3.9-fold (0.59 log units) above; the whole stated range lies above it.
By their numbers in this assay, from the lowest: compounds 4, 1 and 3 (each within the scatter of the next, the first and the last beyond it); then compound 2.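

In this assay, replacing methyl with hydroxy on a saturated chain carbon, two bonds along the chain from a saturated ring carbon, turns propyl into 2-hydroxyethyl and lowers the number beyond the scatter (a 2.7-fold lower number from compound 3 to compound 4 (0.42 log units; beyond the scatter)), so a single hydroxy group on this side chain is not only tolerated but goes with a stronger inhibitor. Until now the only side chain with hydroxy groups was the weakest of the set, yet the gap to the new side chain is large (a 9.7-fold lower number from compound 2 to compound 4 (0.99 log units; beyond the scatter)) and the comparison with the unsaturated side chain of compound 1 stays within the scatter (a 1.6-fold lower number from compound 1 to compound 4 (0.21 log units; within the scatter)), so carrying hydroxy does not by itself raise the number at this position. Nothing measured here explains why the number falls.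

On these data alone, it remains open whether an amine or a methoxy group in the same place would act as hydroxy does, and whether a longer chain ending in hydroxy would hold the value of compound 4 (610 nM). The side chain of compound 2 also differs by its amide and its second hydroxy group, and these four compounds cannot separate those parts.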